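A few compounds are considered here, and "the series" means these few. Any claim that something is new, unique, unknown or untested is made for them only; others in the source may bear on it.

In an ADME assay on microsomes from liver (Homo sapiens) for metabolic stability, read by LC-MS, using NADPH, with stated times of 5 min and 30 min, tested at 1 uM (a lower number here means slower removal, a higher number faster removal of the compound), three compounds have been measured so far:

compound 1 `Cc1nccn1-c1cnc(NCc2c(F)ccc3c2CCO3)c2cn[nH]c(=O)c12`: 8 mL.min-1.g-1
compound 2 `Cc1ncccc1-c1cnc(NCc2c(F)ccc3c2CCO3)c2n[nH]c(=O)n12`: 8 mL.min-1.g-1
compound 3 `COCCC(=O)Nc1cnc(NCc2c(F)ccc3c2CCO3)n2cnnc12`: < 3 mL.min-1.g-1

Compound 1 stands level with compound 2 at the digits given; the two values lie within the scatter of each other, so no order between them can be read. The value of compound 3 is a limit of the assay and not a number, as set out in the limit of < 3 mL.min-1.g-1 in this assay, at which 1 of the 3 values shown sits.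

Compound 4 `Cc1ncccc1-c1cnc(NCc2c(F)ccc3c2CCO3)c2cn[nH]c(=O)c12` differs from compound 1 in one place: 2-methylpyridin-3-yl in place of 2-methyl-1H-imidazol-1-yl on an aromatic carbon. For the measured compounds named here, no pair of measured compounds differing in one place is available, so the size of this change has not been seen directly. Compound 2, which carries the same 2-methylpyridin-3-yl group on a different core, gives 8 mL.min-1.g-1, the same digits as compound 1. On that basis the step of no change at the digits printed from compound 1 to compound 4 (within the scatter) is expected to stay within the scatter, in neither direction. The estimate for compound 4 in this assay is therefore 8 mL.min-1.g-1, with a range from 4 mL.min-1.g-1 to 16 mL.min-1.g-1.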

Compound 4, intrinsic clearance in microsomes: 41 mL.min-1.g-1
Beside the measured number, compound 4's estimate is 5.1-fold (0.71 log units) below it; measured number outside the range, above it.
By their numbers in this assay, from the lowest: compounds 1 and 2 (each within the scatter of the next); then compound 4. At a limit, below all of these: compound 3.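

In this assay, 2-methylpyridin-3-yl in place of 2-methyl-1H-imidazol-1-yl gives a 5.1-fold higher number from compound 1 to compound 4 (0.71 log units; beyond the scatter) on the same core, a step beyond the scatter. For the compounds shown here, this is the first pair differing in one place, and it shows that the group on this aromatic carbon, para to a large group, can shift the read-out even though the rest of the molecule stays unchanged. Nothing measured here accounts for the size or direction of this step.

On these data alone, it remains open whether a phenyl ring, a morpholine or an amine on this carbon would give a number nearer that of compound 1 or that of compound 4. Also open, as far as these compounds go, is whether the methyl group on either ring contributes to the step, and whether the same exchange gives a similar step on the core of compound 2.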